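The compounds below may be only part of what the source reports. "The series", "measured", "known", "first", "only" and "open" are said of these compounds alone.

Working notes on the series. Of the compounds shown here, three on a shared core have been measured in a functional assay on the whole organism (Myocardium) with Canis familiaris (Canis lupus familiaris) as the target, at a dose of 8.75 mg/kg by the intravenous route; a lower number here means that less compound is needed, a higher number that more compound is needed for the effect. Compound 1 `Cc1nc(O)nc2ccccc12` gives 3.45 mg/kg, compound 2 `COc1cc2nc(O)nc(C)c2cc1OC` gives 2.42 mg/kg, and compound 3 `COc1cc(OC)c2c(C)nc(O)nc2c1` gives 2.08 mg/kg. Compound 2 is the middle number of the three, but it lies within the scatter of both compound 1 and compound 3, so these data set no order among them. The three differ from one another in substitution elsewhere on the core, yet their values stay close together.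

The next compound to be measured is compound 4 `CCc1nc(O)nc2cc(OC)c(OC)cc12`. It differs from compound 2 by methyl in place of hydrogen on a saturated chain carbon bound to an aromatic carbon, which turns methyl into ethyl. Going by the values given here, no measured compound carries anything but methyl at this place, so the series offers no direct precedent for the change.

With compound 2 at 2.42 mg/kg as the starting point and only one added carbon, no shift beyond the scatter is expected in this assay. The expected step of a 1.1-fold higher number from compound 2 to compound 4 (0.03 log units; within the scatter) is small, with a slight rise estimated. The estimate for compound 4 is 2.6 mg/kg, with an expected range from 1.4 mg/kg to 4.8 mg/kg.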

Compound 4, dose for half-maximal effect: 3.4 mg/kg
Beside the measured number, compound 4's estimate is 1.3-fold (0.12 log units) below it; the measured number falls inside the stated range.
By their numbers in this assay, from the lowest: compounds 3, 2, 4 and 1 (each within the scatter of the next).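

Going by these compounds alone, the change of methyl to ethyl gives the first reading of any group other than methyl at this place, a saturated chain carbon bound to an aromatic carbon. In this assay, the result is a 1.4-fold higher number from compound 2 to compound 4 (0.15 log units; within the scatter), so this single added methyl gives no shift that can be separated from repeat measurement, and the data set no order between the two compounds. Nothing available bears on the reason for this outcome.

One step on one background cannot show how far this holds, and a longer chain such as propyl, a branched chain such as isopropyl, or an amine or a carboxylic acid carried on this chain would test whether the place stays as undemanding once the group grows or changes in kind. Within the data shown here, it also remains open whether methyl to ethyl reads the same on the substitution patterns of compound 1 and compound 3, where the rest of the core differs from that of compound 2 and no matched step is yet available.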